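Aryl swap on the carbonyl of the boron-bearing chalcone series

The source may report more compounds than this note shows. Statements on the series, on what has been measured and on what is new or still open speak of the compounds shown alone.

Measured compounds:
compound 1 `O=C(/C=C/c1ccc2c(c1)B(O)OC2)c1ccccc1`: 2300 nM
compound 2 `O=C(/C=C/c1ccc2c(c1)B(O)OC2)c1ccco1`: 7300 nM
compound 3 `O=C(/C=C/c1ccc2c(c1)B(O)OC2)c1cccs1`: 4600 nM

In a functional assay on MDA-MB-231 cells (Homo sapiens) for cytotoxicity, read by MTT assay, with a stated time of 48 h (on this read-out higher numbers stand for weaker inhibition and lower numbers for stronger inhibition), compound 1 gives the lowest of the three numbers; compound 3 stands nearest with a 2.0-fold higher number from compound 1 to compound 3 (0.30 log units; within the scatter), and compound 2 furthest with a 3.2-fold higher number from compound 1 to compound 2 (0.50 log units; beyond the scatter). Compound 4 `O=C(/C=C/c1ccc2c(c1)B(O)OC2)c1cccnc1` is not yet measured; it differs from compound 1 as follows: pyridin-3-yl in place of phenyl on a carbonyl carbon. The two steps that replace the phenyl on the carbonyl carbon, a 3.2-fold higher number from compound 1 to compound 2 (0.50 log units; beyond the scatter) and a 2.0-fold higher number from compound 1 to compound 3 (0.30 log units; within the scatter), both went upward, one within the scatter and one modestly beyond it. A pyridin-3-yl keeps one six-membered aromatic ring with 1 hetero atom, so a small upward step is expected, roughly a 1.7-fold higher number from compound 1 to compound 4 (0.24 log units; within the scatter). Compound 4 is therefore estimated at 4000 nM, with a range of 1500 nM to 11000 nM.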

Compound 4, half-maximal inhibitory concentration: 11400 nM
Compound 4: middle estimate off by 2.9-fold (0.45 log units), on the low side, outside the stated range (above it).
By their numbers in this assay, from the lowest: compounds 1, 3, 2 and 4 (each within the scatter of the next, the first and the last beyond it).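

In this assay keeping a six-membered aromatic ring does not hold the number near that of phenyl, with a 5.0-fold higher number from compound 1 to compound 4 (0.70 log units; beyond the scatter) on this carbonyl carbon. Pyridin-3-yl also separates from thiophen-2-yl, with a 2.5-fold higher number from compound 3 to compound 4 (0.39 log units; beyond the scatter) for that swap, while a 1.6-fold higher number from compound 2 to compound 4 (0.19 log units; within the scatter) leaves it level with furan-2-yl. All three replacements of phenyl give higher numbers, though compound 3 stays within the scatter of compound 1.

Nothing shown accounts for this result. As far as these compounds go, whether an amine or a carboxylic acid on the phenyl would move the number at this place remains open.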